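A few compounds are considered here, and "the series" means these few. Any claim that something is new, unique, unknown or untested is made for them only; others in the source may bear on it.

Series notes. For the measured compounds named here, in an assay (Rattus norvegicus) for inhibition of Fatty-acid amide hydrolase 1 (Homo sapiens) (on this read-out higher numbers stand for weaker inhibition and lower numbers for stronger inhibition), compound 3 `O=C(CCCCCCc1ccccc1)c1ncc(-c2ccc([N+](=O)[O-])cc2)o1` gives 50 nM, the lowest of the three numbers so far. Compound 1 `O=C(CCCCCCc1ccccc1)c1ncc(-c2ccccc2F)o1` gives 110 nM and compound 2 `N#Cc1ccccc1-c1cnc(C(=O)CCCCCCc2ccccc2)o1` gives 130 nM; these two sit within the scatter of each other (a 1.2-fold higher number from compound 1 to compound 2 (0.07 log units; within the scatter)). Both steps onto the 4-nitrophenyl ring were modest: a 2.2-fold lower number from compound 1 to compound 3 (0.34 log units; beyond the scatter) and a 2.6-fold lower number from compound 2 to compound 3 (0.41 log units; beyond the scatter). Compound 4 `COc1ccc(-c2cnc(C(=O)CCCCCCc3ccccc3)o2)cc1` carries the change (methoxy in place of nitro on an aromatic carbon), on the same carbon para to a large group. Going by the values given here, no measured pair sets nitro directly against methoxy, so only the size of the steps onto compound 3 guides the expectation: a step back of about their size, toward the level of compound 1 and compound 2. The estimate for compound 4 is 95 nM, expected between 40 nM and 220 nM. The expected step is a 1.9-fold higher number from compound 3 to compound 4 (0.28 log units; within the scatter).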

Compound 4, inhibition constant: 100 nM
The estimate for compound 4 lay 1.1-fold (0.02 log units) below the measured number; measured number inside the range.
By their numbers in this assay, from the lowest: compounds 3, 4, 1 and 2 (each within the scatter of the next, the first and the last beyond it).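

For the compounds shown here, the first direct nitro-to-methoxy comparison on this carbon, para to a large group, gives a 2.0-fold higher number from compound 3 to compound 4 (0.30 log units; within the scatter), so the two para groups cannot be separated here. Compound 4 also cannot be separated from the compounds with a substituted phenyl of another pattern, with a 1.3-fold lower number from compound 2 to compound 4 (0.11 log units; within the scatter) and a 1.1-fold lower number from compound 1 to compound 4 (0.04 log units; within the scatter), and so bridges compound 3 and those two compounds. No measurement at hand accounts for these values.

From the compounds shown here alone, whether an amine or a carboxylic acid on the same carbon would give a step beyond the scatter from compound 3 remains open.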